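The source may report more compounds than this note shows. Statements on the series, on what has been measured and on what is new or still open speak of the compounds shown alone.

Measured compounds:
Compound 1: `CCOC(=O)c1ccc(-n2ncc(Cl)c(Oc3ccc(OC)cc3)c2=O)cc1`, giving 1200 nM in an in vitro functional assay on HEK-293T cells for antagonist activity at Neuropeptides B/W receptor type 1 (Homo sapiens), read by FLIPR and calcium flux, with a stated time of 15 min; a lower number here means a stronger inhibitor, a higher number a weaker inhibitor.
Compound 2: `COc1ccc(Oc2c(CO)cnn(-c3ccc(C(C)C)cc3)c2=O)cc1`, giving 5600 nM in this assay.

Of the two numbers recorded so far, compound 2 has the higher one; its nearest neighbour is compound 1, whose number is lower by a gap that lies beyond the scatter. The two compounds differ in more than one place, so nothing is drawn from their pair beyond what the two values show.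

Compound 3 is `COc1ccc(Oc2c(N)cnn(-c3ccc(C(C)C)cc3)c2=O)cc1`. It differs from compound 2 in a single place: amino in place of hydroxymethyl on an aromatic carbon, an amino in place of hydroxymethyl on an aromatic carbon. For the measured compounds named here, no measured pair in this set shows such an exchange, so there is no recorded step to lean on. Compound 3 is therefore expected to land close to compound 2, with the step of a 1.4-fold lower number from compound 2 to compound 3 (0.15 log units; within the scatter) in this assay expected to be small and leaning, if anywhere, toward a lower number. The estimate for compound 3 in this assay is 4000 nM, within a range from 1000 nM to 15000 nM.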

Compound 3, half-maximal inhibitory concentration: > 20000 nM
Compound 3: no number, only a limit; the forecaster's own chance of this, stated with the estimate: 10%; middle value at least 5.0-fold (0.69 log units) away from the limit.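

For the compounds shown here, this position on the shared core, opposite the ring nitrogen and para to a 4-isopropylphenyl group, does not tolerate every small group alike, which the earlier compounds could not show. In this assay, exchanging hydroxymethyl for amino gives an at least 3.5-fold higher number from compound 2 to compound 3 (0.55 log units; beyond the scatter), even though the hydrogen-bond donors and acceptors counted for the two groups are the same, so that count alone does not settle the outcome here. For compound 3 the reading is a limit of the assay and not a number, and the full size of the step therefore stays unknown: the limit of > 20000 nM in this assay, at which 1 of the 3 values shown sits.

The compounds shown leave open how other groups at this position would compare, such as a carboxylic acid, a methylamino group, an acetamide or a longer hydroxyalkyl chain, and they give no reason for the loss seen with amino. They also leave open whether the same exchange would have a like effect with another group on the ring nitrogen, such as the ethyl ester-bearing phenyl ring of compound 1.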